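Swapping a morpholine side chain for tert-butoxy

A few compounds are considered here, and "the series" means these few. Any claim that something is new, unique, unknown or untested is made for them only; others in the source may bear on it.

Compound 1 `COCCOc1cc2c(-n3nc(-c4ccccn4)nc3N)ncnc2cc1OC` - > 13000 nM
Compound 2 `COc1cc2ncnc(-n3nc(-c4ccccn4)nc3N)c2cc1OCCCNC(=O)CN1C[C@@H](C)O[C@@H](C)C1` - > 25000 nM

Both compounds were tested in an ADME assay on BJ cells (Homo sapiens) for cytotoxicity, with a stated time of 72 h; a higher number here means that more compound is needed for the effect, a lower number that less compound is needed. Compound 1 gives > 13000 nM, which is a limit of the assay. Compound 2 gives > 25000 nM, which is also a limit, so compound 2 has no exact number here.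

Compound 3 `COc1cc2ncnc(-n3nc(-c4ccccn4)nc3N)c2cc1OCCCNC(=O)OC(C)(C)C` carries tert-butoxy in place of (2,6-dimethylmorpholin-4-yl)methyl on a carbonyl carbon. For the measured compounds named here, no measured pair shows what a single change does in this assay. The expected change is therefore none beyond the usual scatter, an estimated a number no higher from compound 2 to compound 3 (the limit leaves the size open). For compound 3 the expected value is 25000 nM, with an estimated range from 10000 nM to 50000 nM.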

Compound 3, half-maximal effective concentration in the BJ assay: > 12000 nM
Compound 3 was reported as a limit; the forecaster's own chance of this, stated with the estimate: 65%; the middle value is on the limit's open side.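

In the BJ assay compound 1 gives > 13000 nM, which is a limit. In the BJ assay compound 2 gives > 25000 nM, which is also a limit. In the BJ assay compound 3 gives > 12000 nM, which is a limit as well. For the compounds shown here, with only limits, no step between them can be read. The compounds shown leave open how much of each compound produces the effect.

In a physicochemical assay for solubility, in phosphate buffer, with a stated time of 18 h, at pH 7.4 (on this read-out lower numbers stand for lower solubility and higher numbers for higher solubility), compound 2 gives 34000 nM and compound 3 gives 2000 nM. In the physicochemical assay tert-butoxy in place of (2,6-dimethylmorpholin-4-yl)methyl on a carbonyl carbon gives a 17-fold lower number from compound 2 to compound 3 (1.23 log units; beyond the scatter).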